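The compounds below may be only part of what the source reports. "The series", "measured", "known", "first", "only" and "open" are said of these compounds alone.

Compound 1 `CCCCNc1ccc(C(=O)N/N=C/c2ccc([N+](=O)[O-])o2)cc1` gives 47000 nM in an ADME assay on LL24 cells (Homo sapiens) for inhibition, read by MTT assay, with a stated time of 24 h; a lower number here means a stronger inhibitor, a higher number a weaker inhibitor.
Compound 2 `CC(C)(C)c1ccc(C(=O)N/N=C/c2ccc([N+](=O)[O-])o2)cc1` reaches only a limit in this assay, > 200000 nM.
Compound 3 `O=C(N/N=C/c1ccc([N+](=O)[O-])o1)c1ccc(-c2ccccc2)cc1` likewise reaches only a limit in this assay, > 200000 nM.

Compound 3 therefore stands at the edge of what this assay can report, at the limit of > 200000 nM in this assay, at which 2 of the 3 values shown sit, so no number is known for it. Compound 4 `N#Cc1ccc(C(=O)N/N=C/c2ccc([N+](=O)[O-])o2)cc1` differs from it in one place: cyano in place of phenyl on an aromatic carbon. For the measured compounds named here, no measured step touches a cyano group, so only the two steps ending at compound 3 give any guide. The step of an at least 4.2-fold higher number from compound 1 to compound 3 (0.62 log units; beyond the scatter) shows that putting phenyl on that aromatic carbon weakened inhibition, while a step that the two limits leave unreadable from compound 2 to compound 3 cannot be sized because both ends are limits. Since compound 3 already sits at a limit, the change in this assay can only show itself if the number falls; a step of an at least 2.0-fold lower number from compound 3 to compound 4 (0.30 log units; that floor lies within the scatter) is expected, though a second limit is nearly as likely. Compound 4 is estimated at 100000 nM, within 30000 nM to 200000 nM.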

Compound 4, half-maximal inhibitory concentration: > 200000 nM
Compound 4 ended at the assay's limit (the forecaster's own chance of this, stated with the estimate: 50%); middle value at least 2.0-fold (0.30 log units) away from the limit.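

Cyano is far smaller than phenyl and brings a hydrogen-bond acceptor, yet compound 4 also gives only a limit in this assay, so neither change lifts it into the readable range. That places a third, quite different group at the same edge of the assay: the limit of > 200000 nM in this assay, at which 3 of the 4 values shown sit. For the compounds shown here, the one readable step is an at least 4.2-fold higher number from compound 1 to compound 4 (0.62 log units; beyond the scatter), which leaves butylamino as the only group on this aromatic carbon, para to a large group, with a measured number.

The steps among compounds 2, 3 and 4 cannot be read, as both ends of each are limits, so any differences among these three groups stay hidden. On these data alone, it also remains open whether the nitrogen of butylamino or its chain matters more, a question that a simple amine or a plain pentyl chain at this position could help to answer.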